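The source may report more compounds than this note shows. Statements on the series, on what has been measured and on what is new or still open speak of the compounds shown alone.

Compound 1 `COc1cccc(-c2nc(SC)nc3sc(C(=O)N(C)C(C)(C)C)c(N)c23)c1`: 3.6%
Compound 2 `CCNC(=O)c1sc2nc(SC)nc(-c3cccc(OC)c3)c2c1N`: 2.3%

In a functional assay on HEK293 cells for agonist activity at Thyrotropin receptor (Homo sapiens), read by cAMP accumulation (a higher number here means a larger maximal response, a lower number a smaller maximal response), compound 2 gives 2.3%, the lowest of the two numbers, with compound 1 nearest at a number 1.3 percentage points lower from compound 1 to compound 2 (within the scatter). The unmeasured compound 3 `COc1cccc(-c2nc(SC)nc3sc(C(=O)NNC(=O)OC(C)(C)C)c(N)c23)c1` differs from compound 2 in one place: (tert-butoxycarbonyl)amino in place of ethyl on an amide-type nitrogen. Within the data shown here, the only measured step changes the group on the same amide-type nitrogen, and that step, from ethylamino to methyl(tert-butyl)amino read backwards, stayed within the scatter at a number 1.3 percentage points lower from compound 1 to compound 2 (within the scatter). Compound 3 is therefore expected to show a step of a number 1.2 percentage points higher from compound 2 to compound 3 (within the scatter), nothing beyond the scatter. The estimate for compound 3 is 3.5%, between 0% and 14%.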

Compound 3, largest response reached (reported as efficacy), in percent of the reference or control that the assay uses: 1.9%
Compound 3: the middle estimate sits 1.6 percentage points above what was measured; measured number inside the range.
By their numbers in this assay, from the lowest: compounds 3, 2 and 1 (each within the scatter of the next).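

In this assay, (tert-butoxycarbonyl)amino in place of ethyl on the amide-type nitrogen gives a number 0.4 percentage points lower from compound 2 to compound 3 (within the scatter), and ((tert-butoxycarbonyl)amino)amino in place of methyl(tert-butyl)amino on the carbonyl carbon gives a number 1.7 percentage points lower from compound 1 to compound 3 (within the scatter). The earlier pair held only simple alkyl groups on this nitrogen; this result shows that a group bringing a hydrogen-bond donor and hydrogen-bond acceptors also leaves the response within the scatter of both earlier compounds. Nothing available explains this result.

As far as these compounds go, whether a free amine, a carboxylic acid or a longer chain at this nitrogen would move the response beyond the scatter remains open.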